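Nitro removal on two related cores in a cell assay

The source may hold more compounds than are shown below. What is called first, only, known or untested is meant among the compounds shown, and "the series" means these compounds.

Measured compounds:
Compound 1, `O=c1nc(-c2ccc([N+](=O)[O-])cc2Cl)ss1`, 28.6%
Compound 2, `O=c1nc(-c2ccccc2Cl)ss1`, 40.1%
Compound 3, `O=c1oc(-c2ccc([N+](=O)[O-])cc2Cl)ns1`, 54.6%

The three measured compounds were tested in an ADME assay on L02 cells (Homo sapiens) for inhibition, read by MTT assay, with a stated time of 48 h, tested at 100 uM; on this read-out higher numbers stand for more inhibition at the one concentration tested (going by the name of the read-out) and lower numbers for less inhibition. Compound 1 gives 28.6% and compound 2 gives 40.1%. These two share one core and differ in a single place: hydrogen in place of nitro on an aromatic carbon. The resulting step is a number 11.5 percentage points higher from compound 1 to compound 2 (beyond the scatter).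

Compound 3 stands on a different core. How its core differs from that of compound 1 is not broken down here. In this assay compound 3 gives 54.6%, the highest of the three numbers. Its gaps to compound 2 and to compound 1 both lie beyond the scatter.

Compound 4, `O=c1oc(-c2ccccc2Cl)ns1`, has not yet been measured. It relates to compound 3 as compound 2 relates to compound 1: hydrogen in place of nitro on an aromatic carbon. The two place descriptions agree word for word, so this is the same change applied on the second core.

For the measured compounds named here, the only guide is the step already seen, a number 11.5 percentage points higher from compound 1 to compound 2 (beyond the scatter), which is modest and beyond the scatter. If the change behaves alike on the second core, compound 4 is expected to lie somewhat above compound 3, an expected step of a number 10.4 percentage points higher from compound 3 to compound 4 (beyond the scatter). Compound 4 is therefore estimated at 65%, with an expected range from 50% to 78%, the width reflecting that a change carried from one core to another need not repeat exactly.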

Compound 4, a percentage reported as inhibition, at one concentration (the size of the read-out at that concentration, not a potency): 20.6%
Estimate against measurement, compound 4: 44.4 percentage points above; measured number outside the range, below it.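

Hydrogen in place of nitro on an aromatic carbon gives, in this assay, a number 34 percentage points lower from compound 3 to compound 4 (beyond the scatter), so on this core the change runs in the opposite direction and the step is large. Set beside the step on the first core, the same change does not carry across the two cores in either direction or size: the same change on two cores in this assay, a number 11.5 percentage points higher (beyond the scatter) from compound 1 to compound 2 and a number 34 percentage points lower (beyond the scatter) from compound 3 to compound 4, 45.5 percentage points apart, beyond the scatter of two such steps Within these four compounds, then, the outcome of removing nitro depends on the core it sits on, but this rests on a single pair per core and on one concentration in one cell line, and it does not show which difference between the cores is responsible, nor which direction would be the more usual one for further cores in the series.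

The compounds shown leave open how an amine or a carboxylic acid on that same aromatic carbon would read on each core, and so whether the split in direction belongs to nitro alone or would appear with other groups as well. They also leave open whether the split would persist if the chloro group were replaced by hydrogen on both cores.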